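A larger group on the aromatic nitrogen of compound 3

A few compounds are considered here, and "the series" means these few. Any claim that something is new, unique, unknown or untested is made for them only; others in the source may bear on it.

Measured in an in vitro ADME assay on microsomes (Homo sapiens) for metabolic stability; on this read-out higher numbers stand for a longer-lived compound and lower numbers for a shorter-lived compound:
Compound 1 `CNC(=O)Nc1ccc(-c2nc(N3CC4CCC(C3)O4)c3cnn(C(C)C)c3n2)cc1` gives 0.2 h as a number
Compound 2 `CNC(=O)Nc1ccc(-c2nc(N3CC4CCC(C3)O4)c3cnn(C4CCC5(CC4)OCCCO5)c3n2)cc1` gives > 0.5 h as a limit of the assay
Compound 3 `CNC(=O)Nc1ccc(-c2nc(N3CC4CCC(C3)O4)c3cnn([C@H]4CC[C@H](OC)CC4)c3n2)cc1` gives 0.25 h as a number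

Compound 3 stands level with compound 1 within the scatter, the step being a 1.3-fold higher number from compound 1 to compound 3 (0.10 log units; within the scatter) on this pair. Compound 4 `CNC(=O)Nc1ccc(-c2nc(N3CC4CCC(C3)O4)c3cnn(C4CCC(OC)(OC)CC4)c3n2)cc1` differs from compound 3 by a group of 10 heavy atoms (8 carbon, 2 oxygen; one six-membered non-aromatic ring of carbon only) in place of a group of 8 heavy atoms (7 carbon, 1 oxygen; one six-membered non-aromatic ring of carbon only), on an aromatic nitrogen at that same nitrogen. For the measured compounds named here, two measured steps bear on this change, namely an at least 2.5-fold higher number from compound 1 to compound 2 (0.39 log units; beyond the scatter) and an at least 2.0-fold lower number from compound 2 to compound 3 (0.30 log units; that floor lies within the scatter) in the same place. The entering group lies nearer in size to that of compound 2, so a small rise is expected. The expected step is a 1.4-fold higher number from compound 3 to compound 4 (0.15 log units; within the scatter) and it is estimated to stay within the scatter. Compound 4 is estimated at 0.35 h with an expected range from 0.15 h to 0.7 h in this assay for now.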

Compound 4, half-life: 0.5 h
Compound 4: the middle estimate sits 1.4-fold (0.15 log units) below what was measured, and the stated range covers the measured number.
By their numbers in this assay, from the lowest: compounds 1, 3 and 4 (each within the scatter of the next, the first and the last beyond it).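

In this assay the group entering in place of 4-methoxycyclohexyl gives a 2.0-fold higher number from compound 3 to compound 4 (0.30 log units; within the scatter) and so these two compounds stand level. Against isopropyl the same group gives a 2.5-fold higher number from compound 1 to compound 4 (0.40 log units; beyond the scatter) and this shows that a group without the second ring of compound 2 can also clear the scatter from compound 1. The last step is a number no higher from compound 2 to compound 4 (the limit leaves the size open) and it cannot be read, as compound 2 stands at a limit of the assay: the limit of > 0.5 h in this assay, at which 1 of the 4 values shown sits.

The compounds shown leave open how far compound 2 lies from compound 4. They also leave open how an amine or a carboxylic acid on this cyclohexyl ring would compare.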